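The source may hold more compounds than are shown below. What is called first, only, known or untested is meant among the compounds shown, and "the series" means these compounds.

Measured so far:

Compound 1, `CCOC(=O)Cn1cc(CNC(=O)c2cn(CCOC(C)=O)nn2)nn1`. In a functional assay on B16 cells (Mus musculus) for cytotoxicity, read by MTT assay, with a stated time of 48 h (on this read-out lower numbers stand for stronger inhibition and higher numbers for weaker inhibition), compound 1 gives > 100000 nM, which is a limit of the assay and not a number.

Compound 2, `CC(=O)OCCn1cc(CNC(=O)c2cn(CCOC(C)=O)nn2)nn1`. In this assay compound 2 gives > 100000 nM, again a limit rather than a number.

Compound 3, `CCOC(=O)Cn1cc(C(=O)Nc2ccccc2)nn1`. In this assay compound 3 gives > 100000 nM, also a limit rather than a number.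

Compound 1 and compound 2 share a core and differ in one place: acetoxymethyl in place of ethoxycarbonyl on a saturated chain carbon bound to an aromatic nitrogen. Because both values sit at the limit of > 100000 nM in this assay, at which 3 of the 3 values shown sit, this step reads as a step that the two limits leave unreadable from compound 1 to compound 2, and its size cannot be read from these two compounds. The core of compound 3 is a different one, and the difference between the two cores is not broken down here.

Compound 4, `CC(=O)OCCn1cc(C(=O)Nc2ccccc2)nn1`, has not yet been measured. It stands to compound 3 as compound 2 stands to compound 1, by the same change at the same place: acetoxymethyl in place of ethoxycarbonyl on a saturated chain carbon bound to an aromatic nitrogen.

For the measured compounds named here, for compound 4 in this assay the expectation rests on two things: compound 3 gives > 100000 nM, and the one earlier example of this change, a step that the two limits leave unreadable from compound 1 to compound 2, stayed at the limit on both sides. The step from compound 3 to compound 4 is therefore expected to be a step that the limit leaves unreadable from compound 3 to compound 4. Compound 4 is estimated to give about 150000 nM, most likely reported as a limit again, with a plausible range from 50000 nM to 600000 nM.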

Compound 4, half-maximal inhibitory concentration: > 100000 nM
Compound 4 was reported as a limit; the forecaster's own chance of this, stated with the estimate: 85%; the middle value lies beyond the limit too.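

In this assay neither compound 3 nor compound 4 gives a number, so the step between them cannot be read, each value being only a limit: the limit of > 100000 nM in this assay, at which 4 of the 4 values shown sit. The compounds shown leave open whether putting acetoxymethyl in place of ethoxycarbonyl changes cytotoxicity at all, and which structure would bring a value in this assay inside the measurable range.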